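Extending a chain and then decorating its anchor

The source may report more compounds than this note shows. Statements on the series, on what has been measured and on what is new or still open speak of the compounds shown alone.

Two compounds share a core and an amide ending in a dichlorophenyl group. Compound 1 `Cn1c(Cc2nn(C)c(=O)c3ccccc23)nnc1SCC(=O)Nc1ccc(Cl)cc1Cl` links the core to the amide through a short sulfur-bearing chain, and in an assay on 32D cells for inhibition of interleukin-15 (Mus musculus), read by resazurin assay, with stated times of 30 min and 2.5 days, in the presence of a further agent that is not named here (a higher number here means a weaker inhibitor, a lower number a stronger inhibitor), compound 1 gives 21100 nM. Compound 2 `Cn1c(Cc2nn(C)c(=O)c3ccccc23)nnc1SCCCCCCCC(=O)Nc1ccc(Cl)cc1Cl` lengthens that chain, and in this assay compound 2 gives 3900 nM. Compound 2 therefore stands lowest of the two numbers, and its gap to compound 1 lies beyond the scatter.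

Compound 3 `Cn1nc(Cc2nnc(SCCCCCCCC(=O)Nc3ccc(Cl)cc3Cl)n2CCCO[Si](C)(C)C(C)(C)C)c2ccccc2c1=O` keeps everything in compound 2 and adds (a group of 10 heavy atoms (8 carbon, 1 oxygen, 1 silicon; no ring) in place of a hydrogen atom, on a saturated chain carbon bound to an aromatic nitrogen). Going by the values given here, the new group is large and carries a silicon atom, and no measured pair shows what such an addition does to this series. With only two points available, the expectation rests on the shared core and chain being retained; the added group is assumed neither to help nor to hurt strongly, with a lean toward a slightly weaker result.

The expected step of a 1.5-fold higher number from compound 2 to compound 3 (0.19 log units; within the scatter) is therefore small. For compound 3 in this assay the estimate is 6000 nM, with a range from 1500 nM to 25000 nM.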

Compound 3, half-maximal inhibitory concentration: > 30000 nM
Compound 3 ended at the assay's limit (the forecaster's own chance of this, stated with the estimate: 10%); middle value at least 5.0-fold (0.69 log units) away from the limit.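

Compound 1 and compound 2 both carry only hydrogen at this place, so they gave no sign of how the series responds to a change there. In this assay, a group of 10 heavy atoms (8 carbon, 1 oxygen, 1 silicon; no ring) in place of a hydrogen atom, on a saturated chain carbon bound to an aromatic nitrogen, brings an at least 7.6-fold higher number from compound 2 to compound 3 (0.88 log units; beyond the scatter), which shows that this place is not indifferent to what is attached to it. Compound 3 gives > 30000 nM, which is a limit of the assay and not a number, so the step marks only the smallest possible change and its true size stays unknown: the limit of > 30000 nM in this assay, at which 1 of the 3 values shown sits.

As far as these compounds go, it remains open whether a smaller addition at this place, such as a hydroxyl group or an amine at the end of the same chain, would keep the value of compound 2. From the compounds shown here alone, it is also open whether the loss belongs to the whole group or only to its silicon-bearing end, and a single group at one place cannot separate these two readings.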